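Ethyl to 4-bromophenyl on the ether oxygen

The source may report more compounds than this note shows. Statements on the series, on what has been measured and on what is new or still open speak of the compounds shown alone.

In a functional assay on A549 cells (Homo sapiens) for inhibition, read by sulforhodamine B assay, with a stated time of 48 h, tested at 50 uM (a lower number here means less inhibition of growth, a higher number more inhibition of growth at the concentration tested), compound 1 (`CCCOc1ccc([C@@H]2CC(=O)c3cc(CC=C(C)C)c(OC)cc3O2)cc1`) gives 43% and compound 2 (`CCOc1ccc([C@@H]2CC(=O)c3cc(CC=C(C)C)c(OC)cc3O2)cc1`) gives 37%. Going by the values given here, compound 2 therefore stands within the scatter of compound 1, the only other measured member of the series.

The next compound is compound 3 (`COc1cc2c(cc1CC=C(C)C)C(=O)C[C@@H](c1ccc(Oc3ccc(Br)cc3)cc1)O2`), which has 4-bromophenyl in place of ethyl on an oxygen on an aromatic ring.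

Among the compounds with values here, only one measured step bears on this change: a number 6 percentage points lower from compound 1 to compound 2 (within the scatter). It alters the group on the same oxygen, but by a single methyl only, and it gives no firm trend. Within the data shown here, the change to compound 3 is much bigger, and no measured compound carries an aromatic ring on that oxygen, so the direction remains poorly supported. A small rise is the working expectation, with no step beyond the scatter firmly expected in this assay. The estimated change is a number 8 percentage points higher from compound 2 to compound 3 (within the scatter). For compound 3 the estimated value is 45%, with an expected range of 25% to 68%.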

Compound 3, percent growth inhibition at one concentration: 72%
For compound 3 the middle estimate is 27 percentage points below the measured one; measured number above the stated range.
By their numbers in this assay, from the lowest: compounds 2 and 1 (each within the scatter of the next); then compound 3.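

At the ether oxygen the group clearly matters in this assay: 4-bromophenyl in place of ethyl gives a number 35 percentage points higher from compound 2 to compound 3 (beyond the scatter), and 4-bromophenyl in place of propyl gives a number 29 percentage points higher from compound 1 to compound 3 (beyond the scatter). The two alkyl ethers differ only within the scatter, so this position showed no clear response until the short chain was replaced by a group carrying a six-membered aromatic ring and a bromine. No measurement available here explains the rise.

As far as these compounds go, the ring and the bromine enter together in compound 3, so their separate contributions remain open; an unsubstituted phenyl ether and a 4-chlorophenyl ether would be the direct comparisons. Also open, from the compounds shown here alone, is whether the aromatic ring must sit directly on the oxygen or whether a benzyl ether would serve as well, and whether a longer chain such as butyl or a chain ending in an amine would reach a similar number at the single concentration tested.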